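A few compounds are considered here, and "the series" means these few. Any claim that something is new, unique, unknown or untested is made for them only; others in the source may bear on it.

Measured compounds:
Compound 1, `COc1cccc(NC(=O)NCC2(c3ccccc3)CCCCC2)c1`, in an assay on microsomes from intestine for inhibition of acyl-CoA:cholesterol acyltransferase (Oryctolagus cuniculus) (on this read-out higher numbers stand for weaker inhibition and lower numbers for stronger inhibition), gives 2500 nM.
Compound 2, `Cc1cccc(NC(=O)NCC2(c3ccccc3)CCCCC2)c1`, in this assay gives 2800 nM.
Compound 3, `COc1ccc(NC(=O)NCC2(c3ccccc3)CCCCC2)cc1`, in this assay gives 4900 nM.

The three measured compounds share a core and differ only on the aryl ring. Compound 1 and compound 3 have the same atoms joined differently: 4-methoxyphenyl in place of 3-methoxyphenyl on an amide-type nitrogen. The step of a 2.0-fold higher number from compound 1 to compound 3 (0.29 log units; within the scatter). Likewise a 1.8-fold higher number from compound 2 to compound 3 (0.24 log units; within the scatter).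

Compound 4, `Cc1ccc(NC(=O)NCC2(c3ccccc3)CCCCC2)cc1`, is not yet measured. Its difference from compound 3 is methyl in place of methoxy on an aromatic carbon. The same kind of change is already known from compound 1 to compound 2, (methyl in place of methoxy on an aromatic carbon), where the step was a 1.1-fold higher number from compound 1 to compound 2 (0.05 log units; within the scatter). The two places are not identical: in the known pair the group sits meta to a large group, in the new pair para to a large group, so it is the same kind of change rather than the same one.

Because a 1.1-fold higher number from compound 1 to compound 2 (0.05 log units; within the scatter), compound 4 is expected to sit close to compound 3, with an estimated step of a 1.1-fold higher number from compound 3 to compound 4 (0.04 log units; within the scatter). The estimate for compound 4 in this assay is 5400 nM, with a range from 2500 nM to 12000 nM.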

Compound 4, half-maximal inhibitory concentration: 4500 nM
Estimate against measurement, compound 4: 1.2-fold (0.08 log units) above, and the stated range covers the measured number.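

In this assay, the exchange of methoxy for methyl gives the same result on both cores, with no difference that the read-out can resolve: the same change on two cores in this assay, a 1.1-fold higher number (0.05 log units; within the scatter) from compound 1 to compound 2 and a 1.1-fold lower number (0.04 log units; within the scatter) from compound 3 to compound 4, 1.2-fold (0.09 log units) apart, within the scatter of two such steps The new step, a 1.1-fold lower number from compound 3 to compound 4 (0.04 log units; within the scatter), sits among others that are just as unresolved, namely a 1.6-fold higher number from compound 2 to compound 4 (0.21 log units; within the scatter) and a 1.8-fold higher number from compound 1 to compound 4 (0.26 log units; within the scatter), so none of the four compounds separates from the rest. This shows that, for these two pairs, the exchange carries over from the core of compound 1 to the core of compound 3 without a measurable change, but two steps this small do not show that it would stay small on other cores, and they give no rule for the series.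

The compounds shown carry only methoxy or methyl on the aryl ring, so it remains open whether chlorine, an amine or a carboxylic acid in the same place would give a number beyond the scatter. Also open, going by these compounds, is whether the exchange would behave alike with a longer chain on the amide-type nitrogen.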